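This account rests on a few compounds, and the source may have more. Where it says the series, first, only, none or still open, it means among the compounds named here.

Working notes on a three-compound set with one open position.

The series is read in a functional assay on HCT-15 cells (Homo sapiens) for cytotoxicity, read by CCK-8 assay; on this read-out higher numbers stand for weaker inhibition and lower numbers for stronger inhibition. Compound 1 `Oc1cccc(-c2cc(-c3ccsc3)cc(-c3cccc(O)c3)n2)c1` gives 1630 nM. Compound 2 `Oc1ccc(-c2cc(-c3ccsc3)cc(-c3cccc(O)c3)n2)cc1` gives 1180 nM; the change between them is 4-hydroxyphenyl in place of 3-hydroxyphenyl on an aromatic carbon, and the step is a 1.4-fold lower number from compound 1 to compound 2 (0.14 log units; within the scatter). Compound 3 `Oc1ccc(-c2cc(-c3ccoc3)cc(-c3cccc(O)c3)n2)cc1` gives 930 nM, with the step of a 1.3-fold lower number from compound 2 to compound 3 (0.10 log units; within the scatter). Compound 3 has the lowest of the three numbers, yet all three values lie within the scatter of one another, so no order among them is claimed. The difference between the core of compound 1 and the core of compound 3 is not broken down here.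

Compound 4 `Oc1ccc(-c2cc(-c3ccoc3)cc(-c3ccc(O)cc3)n2)cc1` remains to be measured in this assay. Relative to compound 3 the change is 4-hydroxyphenyl in place of 3-hydroxyphenyl on an aromatic carbon. It is the same kind of change as that from compound 1 to compound 2, but not the same: in compound 1 the position is meta to a 3-hydroxyphenyl group and meta to a thiophen-3-yl group, whereas in compound 3 it is meta to a 4-hydroxyphenyl group and meta to a furan-3-yl group.

Expectation for compound 4 rests on compound 1 and compound 2, because a 1.4-fold lower number from compound 1 to compound 2 (0.14 log units; within the scatter) is the only instance of this change that has been measured. The step is expected to be of similar size, a 1.3-fold lower number from compound 3 to compound 4 (0.12 log units; within the scatter). The number for compound 4 is estimated at 700 nM, expected to fall between 350 nM and 1400 nM.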

Compound 4, half-maximal inhibitory concentration: 1530 nM
Beside the measured number, compound 4's estimate is 2.2-fold (0.34 log units) below it; the whole stated range lies below it.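

In this assay the new step reads a 1.6-fold higher number from compound 3 to compound 4 (0.22 log units; within the scatter). Set beside the earlier instance of the same change, the two steps do not separate: the same change on two cores in this assay, a 1.4-fold lower number (0.14 log units; within the scatter) from compound 1 to compound 2 and a 1.6-fold higher number (0.22 log units; within the scatter) from compound 3 to compound 4, 2.3-fold (0.36 log units) apart, within the scatter of two such steps. On the cores of compound 1 and compound 3, then, 4-hydroxyphenyl in place of 3-hydroxyphenyl gives no step beyond the scatter, and the difference in direction between the two steps is not to be read as real; what this does not show is that the change carries over unchanged from one core to another, as two small steps can neither establish such transfer nor reveal a dependence on the core.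

The compounds shown vary only the hydroxyl placement on the phenyl groups and furan-3-yl against thiophen-3-yl, and every step among them stays within the scatter, so they do not show what in this series can move the number by more than that. Open, therefore, is what this assay would report with an amine or a carboxylic acid in place of the hydroxyl on these phenyl groups, or with a longer chain on the shared core.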